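Swapping an Amide Link for an Ether on a Flexible Side Chain

The compounds below may be only part of what the source reports. "The series", "measured", "known", "first", "only" and "open" are said of these compounds alone.

Measured compounds:
compound 1, `COc1ccc(C(=O)NCCCOc2cc(=O)n(CCCO)c3c2CC(C/C=C(\C)CCC=C(C)C)C(C)(C)C3)cc1`, 14.1%
compound 2, `CC(C)=CCC/C(C)=C/CC1Cc2c(OCCCNC(=O)c3cccs3)cc(=O)n(CCCO)c2CC1(C)C`, 11.5%

In a functional assay on PANC-1 cells (Homo sapiens) for inhibition, read by MTT assay, with a stated time of 24 h, tested at 10 uM (a lower number here means less inhibition, a higher number more inhibition at the concentration tested (going by the name of the read-out)), compound 2 gives 11.5%, the lowest of the two numbers, with compound 1 nearest at 14.1%. For the measured compounds named here, the one recorded step, a number 2.6 percentage points lower from compound 1 to compound 2 (within the scatter), lies within the scatter. Compound 3, `COc1ccc(OCCCOc2cc(=O)n(CCCO)c3c2CC(C/C=C(\C)CCC=C(C)C)C(C)(C)C3)cc1`, carries the change (4-methoxyphenoxy in place of ((thiophen-2-yl)carbonyl)amino on a saturated chain carbon, three bonds along the chain from an oxygen on an aromatic ring). Going by the values given here, no measured step covers this change, so the numbers give little guidance beyond the low range seen so far. Compound 3 is therefore expected to show 13%, between 3% and 25%, a step of a number 1.5 percentage points higher from compound 2 to compound 3 (within the scatter).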

Compound 3, a percentage reported as inhibition, at one concentration (the size of the read-out at that concentration, not a potency): 0%
Estimate against measurement, compound 3: 13 percentage points above, outside the stated range (below it).
By their numbers in this assay, from the lowest: compound 3; then compounds 2 and 1 (each within the scatter of the next).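

In this assay, changing the ring on the carbonyl moved the number only within the scatter, but replacing the carbonylamino link with an oxygen has a larger effect. With the 4-methoxyphenyl ring kept, there is a number 14.1 percentage points lower from compound 1 to compound 3 (beyond the scatter), and the thiophene pair shows a number 11.5 percentage points lower from compound 2 to compound 3 (beyond the scatter). Nothing available explains this loss of inhibition. The compounds shown leave open which part of the carbonylamino link matters, the carbonyl or the amide hydrogen. A plain amine as the link, or a longer chain carrying the amide, could help to separate these.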